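This account rests on a few compounds, and the source may have more. Where it says the series, first, only, none or still open, it means among the compounds named here.

Working notes on the amide aryl group of this series. The shared core is set; what changes is the aryl group on the carbonyl carbon. Compound 1 `Cn1cnc(S(=O)(=O)N2C[C@@H]3[C@H](C2)[C@@]3(CNC(=O)c2ccccc2C(F)(F)F)CC2CC2)c1` carries a 2-(trifluoromethyl)phenyl there and in an assay on isolated protein for inhibition of sodium- and chloride-dependent glycine transporter 1 (Homo sapiens) (a higher number here means a weaker inhibitor, a lower number a stronger inhibitor), compound 1 gives 5 nM. Going by the values given here, compound 2 `Cn1cnc(S(=O)(=O)N2C[C@@H]3[C@H](C2)[C@@]3(CNC(=O)c2c(Cl)cccc2Cl)CC2CC2)c1` carries a 2,6-dichlorophenyl instead, and in this assay compound 2 gives 28 nM, the higher of the two numbers measured so far; the step of a 5.6-fold higher number from compound 1 to compound 2 (0.75 log units; beyond the scatter) is the only measured step and it concerns the same position.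

Compound 3 `Cn1cnc(S(=O)(=O)N2C[C@@H]3[C@H](C2)[C@@]3(CNC(=O)c2ccc(Cl)cc2)CC2CC2)c1` is the next compound, differing from compound 2 by 4-chlorophenyl in place of 2,6-dichlorophenyl on a carbonyl carbon. The step from compound 1 to compound 2 shows that exchanging the aryl group at this position moves the number by a modest amount, beyond the scatter. Among the compounds with values here, no measured pair shows the effect of removing both chlorines and placing one elsewhere on the ring, so the direction of the step is uncertain; a step of roughly the size seen from compound 1 to compound 2, in either direction, is expected, and the estimate is set slightly above compound 2 as a 1.6-fold higher number from compound 2 to compound 3 (0.21 log units; within the scatter). For compound 3 in this assay the expected value is 45 nM, with a range from 12 nM to 180 nM.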

Compound 3, half-maximal inhibitory concentration: 32 nM
Beside the measured number, compound 3's estimate is 1.4-fold (0.15 log units) above it; low and high end bracket the measured number.
By their numbers in this assay, from the lowest: compound 1; then compounds 2 and 3 (each within the scatter of the next).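

Read in this assay, the step of a 1.1-fold higher number from compound 2 to compound 3 (0.06 log units; within the scatter) shows that this position does not separate a 2,6-dichlorophenyl from a 4-chlorophenyl, even though the two groups differ in their number of chlorines and where these sit on the ring. The step of a 6.4-fold higher number from compound 1 to compound 3 (0.81 log units; beyond the scatter) places the second chlorophenyl group on the same side of compound 1 as the first, so among the three compounds, the 2-(trifluoromethyl)phenyl of compound 1 alone gives the lower number. Nothing available here explains why these aryl groups read as they do.

Still open, as far as these compounds go, is whether the lower number of compound 1 goes with the trifluoromethyl group itself or with the particular 2-substituted arrangement, a question that a 4-(trifluoromethyl)phenyl or a 2-chlorophenyl on the same carbonyl carbon would address. Also open, from the compounds shown here alone, is how this position responds to groups of other kinds, such as a pyridyl ring, a methoxy group or a nitrile on the phenyl ring.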